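Swapping methoxy for methyl in compound 1

A few compounds are considered here, and "the series" means these few. Any claim that something is new, unique, unknown or untested is made for them only; others in the source may bear on it.

- compound 1 `COc1ccccc1CN1CCC=C(CCC(=O)NO)C1=O` gives > 10000 nM
- compound 2 `O=C(CCC1=CCCN(Cc2ccc3ccccc3c2)C1=O)NO` gives "not determined" (no result reported)

Both compounds were taken to a functional assay on ACHN cells (Homo sapiens) for inhibition, read by sulforhodamine B assay (a lower number here means a stronger inhibitor of growth, a higher number a weaker inhibitor of growth), but neither yields an exact number. Compound 1 gives > 10000 nM in this assay and this is a limit of the assay, not a number. The wider picture is the limit of > 10000 nM in this assay, at which 1 of the 2 values shown sits, and compound 2 adds nothing to it, with the entry "not determined" (no result reported) standing in place of a result. Within the data shown here, no pair of measured compounds therefore shows how large a single structural change can be here.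

Compound 3 `Cc1ccccc1CN1CCC=C(CCC(=O)NO)C1=O` keeps the core of compound 1 and has methyl in place of methoxy on an aromatic carbon, ortho to a large group (methyl in place of methoxy on an aromatic carbon). Among the measured compounds shown here, with no measured step as a guide, no step beyond the usual scatter is expected in this assay, and no direction is favoured. The estimate therefore stays close to the limit of compound 1. The expected step is a step that the limit leaves unreadable from compound 1 to compound 3 and it is only an estimate. The assay may again report only a limit. Compound 3 is expected at 15000 nM (estimated range 5000 nM to 50000 nM).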

Compound 3, concentration for 50% growth inhibition: > 10000 nM
Compound 3: a limit, no number; the forecaster's own chance of this, stated with the estimate: 70%; the middle value does not contradict the limit.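

In this assay compound 3 gives > 10000 nM, which is a limit of the assay and not a number. Compound 1 also gives only a limit, so no step can be read between compound 1 and compound 3. The compounds shown leave open how strongly either one inhibits growth, and whether methyl in place of methoxy changes it, with the picture still resting on: the limit of > 10000 nM in this assay, at which 2 of the 3 values shown sit.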